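Swapping a thioether ring for a methylpiperazine on the amide

The source may hold more compounds than are shown below. What is called first, only, known or untested is meant among the compounds shown, and "the series" means these compounds.

Measured so far, in a functional assay on HT-29 cells (Homo sapiens) for cytotoxicity, read by MTT assay, with a stated time of 24 h, tested at 32 ug/mL; a higher number here means a stronger effect of the compound at the concentration tested, a lower number a weaker effect:
- compound 1 `Cn1c(-c2ccc(NC(=O)CSc3nc4ccccc4s3)cc2)nc(-c2ccccc2)c1-c1ccccc1`: 66%
- compound 2 `Cc1nnc(SCC(=O)Nc2ccc(-c3nc(-c4ccccc4)c(-c4ccccc4)n3C)cc2)s1`: 87.1%
- compound 3 `Cn1c(-c2ccc(NC(=O)CSC3=NCCS3)cc2)nc(-c2ccccc2)c1-c1ccccc1`: 59.4%

Compound 3 sits at the low end of these three numbers: one of its two steps is a number 6.6 percentage points lower from compound 1 to compound 3 (within the scatter), within the scatter, while the other, a number 27.7 percentage points lower from compound 2 to compound 3 (beyond the scatter), lies beyond it. Compound 4 `CN1CCN(CC(=O)Nc2ccc(-c3nc(-c4ccccc4)c(-c4ccccc4)n3C)cc2)CC1` differs from compound 3 in one place: a group of 7 heavy atoms (5 carbon, 2 nitrogen; one six-membered non-aromatic ring with 2 hetero atoms) in place of a group of 6 heavy atoms (3 carbon, 1 nitrogen, 2 sulfur; one five-membered non-aromatic ring with 2 hetero atoms), on a saturated chain carbon bound to a carbonyl carbon. Within the data shown here, no measured step touches this place; the steps known, a number 21.1 percentage points higher from compound 1 to compound 2 (beyond the scatter) and a number 27.7 percentage points lower from compound 2 to compound 3 (beyond the scatter), only swap the ring on the sulfur, and they show that changes at this end of the shared core move the read-out by modest amounts. The expectation is therefore a step of a number 1.4 percentage points lower from compound 3 to compound 4 (within the scatter) from compound 3. Compound 4 is estimated at 58%, in a range from 30% to 85%.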

Compound 4, a percentage reported as activity, at one concentration (the size of the read-out at that concentration, not a potency): 49.1%
For compound 4 the middle estimate is 8.9 percentage points above the measured one; measured number inside the range.
By their numbers in this assay, from the lowest: compound 4; then compounds 3 and 1 (each within the scatter of the next); then compound 2.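

In this assay, putting 4-methylpiperazin-1-yl on the saturated chain carbon bound to a carbonyl carbon gives the first step measured at this place: a number 10.3 percentage points lower from compound 3 to compound 4 (beyond the scatter). Measured against the two aromatic rings on sulfur, the same place gives a number 16.9 percentage points lower from compound 1 to compound 4 (beyond the scatter) and a number 38 percentage points lower from compound 2 to compound 4 (beyond the scatter). Compound 4 is thus the weakest of the four, and the size of the loss depends on which group it replaces.

No other data bear on why the read-out falls. On these data alone, whether a morpholine ring or a dimethylamino group at this place would behave like 4-methylpiperazin-1-yl remains open.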